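The source may report more compounds than this note shows. Statements on the series, on what has been measured and on what is new or still open speak of the compounds shown alone.

Measured so far in a functional assay on thoracic aorta (Rattus norvegicus, strain Wistar), with a stated time of 15 min; on this read-out lower numbers stand for an effect already at smaller amounts and higher numbers for an effect only at larger amounts of compound:
- compound 2 `CCOc1ccc(Cl)cc1C(C)NC(=O)N(C)S(=O)(=O)c1ccc(C)cc1`: 12200 nM
- compound 1 `CCOc1ccc(F)cc1C(C)NC(=O)N(C)S(=O)(=O)c1ccc(Cl)cc1`: 24500 nM

For the measured compounds named here, compound 2 and compound 1 give numbers that differ by an amount within the usual scatter, so the two cannot be told apart on these data; no step between them is counted here, as they differ in more than one place.

Compound 3 `CCOc1ccc(Cl)cc1C(C)NC(=O)N(C)S(=O)(=O)c1ccc(Cl)cc1` remains to be measured in this assay. It differs from compound 2 in one place: chloro in place of methyl on an aromatic carbon. The pair differs in the same kind of group that already varies between compound 1 and compound 2, where no difference beyond the scatter was seen.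

Going by the values given here, with only two measured compounds and no counted step, the change from compound 2 to compound 3 is expected to move the read-out by no more than the scatter, in no preferred direction, so a 1.1-fold higher number from compound 2 to compound 3 (0.06 log units; within the scatter) is the estimated step. For compound 3 the expected value in this assay is 14000 nM, with a range from 5000 nM to 40000 nM.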

Compound 3, half-maximal effective concentration: 14600 nM
For compound 3 the middle estimate is 1.0-fold (0.02 log units) below the measured one; low and high end bracket the measured number.
By their numbers in this assay, from the lowest: compounds 2, 3 and 1 (each within the scatter of the next).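

In this assay, for the compounds shown here, chloro in place of methyl on the aromatic carbon para to a large group gives a 1.2-fold higher number from compound 2 to compound 3 (0.08 log units; within the scatter) as the first single-place reading at this position, and on these data the two groups cannot be told apart there. Compound 3 also gives a single-place reading at a second aromatic position, where chloro in place of fluoro gives a 1.7-fold lower number from compound 1 to compound 3 (0.22 log units; within the scatter) and again no difference can be read. No supporting measurement bears on either step.

From the compounds shown here alone, whether any group at the position para to a large group can move the number beyond the scatter remains open, for example an amine or a carboxylic acid in place of chloro. Also open, going by these compounds, is whether a longer chain in place of the ethoxy group changes the read-out in this assay at all.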